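Small Methyl Added Where Nothing Was Yet Measurable

A few compounds are considered here, and "the series" means these few. Any claim that something is new, unique, unknown or untested is made for them only; others in the source may bear on it.

Compound 2 `Cc1ccc2c(NCc3ccc(NC(=O)C4CCN(Cc5ccccc5)CC4)cc3)nc(N3CCN(C)CC3)nc2c1` was tested in a functional assay on SV5A8 cells (Homo sapiens) for cytotoxicity; on this read-out lower numbers stand for stronger inhibition and higher numbers for weaker inhibition. There compound 2 gives > 17700 nM, which is a limit of the measurement rather than a number. Compound 1 `Cc1ccc2c(NCc3ccc(NC(=O)C4CCN(Cc5ccccc5)CC4)cc3)nc(N(C)CCN(C)C)nc2c1` differs from it in one place; in this assay compound 1 gives > 8830 nM, likewise a limit. The step that the two limits leave unreadable from compound 1 to compound 2 cannot be read because the limit of > 17700 nM in this assay, at which 1 of the 2 values shown sits, and the limit of > 8830 nM in this assay, at which 1 of the 2 values shown sits, are both boundaries of the measurement.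

Compound 3 `CCN1CCN(c2nc(NCc3ccc(NC(=O)C4CCN(Cc5ccccc5)CC4)cc3)c3ccc(C)cc3n2)CC1` carries methyl in place of hydrogen on a saturated chain carbon bound to an amine nitrogen in a ring. Going by the values given here, no measured step resembles this change, so no shift beyond the scatter is expected. Compound 3 is estimated at 25000 nM, within 8000 nM to 80000 nM, most likely again only a limit. The expected step is a step that the limit leaves unreadable from compound 2 to compound 3.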

Compound 3, half-maximal inhibitory concentration: > 13000 nM
Compound 3: a limit, no number; the forecaster's own chance of this, stated with the estimate: 80%; the middle value lies beyond the limit too.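

In this assay, going by these compounds alone, compound 3 gives > 13000 nM, again a limit and not a number, so no step among compound 1, compound 2 and compound 3 can be read. On these data alone, what stays open is the actual strength of each of these three compounds on these cells.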